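Ring Expansion at the Piperidine Nitrogen Substituent

The source may hold more compounds than are shown below. What is called first, only, known or untested is meant among the compounds shown, and "the series" means these compounds.

Compound 1 `CS(=O)(=O)c1cnc(O[C@H]2CC[C@H](OC3CCN(C(=O)OC4CCOC4)CC3)CC2)cn1` gives 105% in a functional assay on isolated protein for agonist activity at Glucose-dependent insulinotropic receptor (Homo sapiens), read by HTRF and cAMP accumulation; a lower number here means a smaller maximal response, a higher number a larger maximal response. Compound 2 `CS(=O)(=O)c1cnc(O[C@H]2CC[C@H](OC3CCN(CC4(C(F)(F)F)CC4)CC3)CC2)cn1` reaches 116% and stands highest of the two values, the step of a number 11 percentage points higher from compound 1 to compound 2 (beyond the scatter) lying beyond the scatter. Compound 3 `CS(=O)(=O)c1cnc(O[C@H]2CC[C@H](OC3CCN(CC4(C(F)(F)F)CCC4)CC3)CC2)cn1` differs from compound 2 by 1-(trifluoromethyl)cyclobutyl in place of 1-(trifluoromethyl)cyclopropyl on a saturated chain carbon bound to an amine nitrogen in a ring. No measured step tests this change; the only step shown concerns a different substituent on the same nitrogen, so the author expects no change beyond the scatter, a number 3 percentage points lower from compound 2 to compound 3 (within the scatter). Compound 3 is estimated at 113%, between 98% and 128%.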

Compound 3, largest response reached (Emax), in percent of the reference or control that the assay uses: 96%
Compound 3: middle estimate off by 17 percentage points, on the high side; measured number outside the range, below it.
By their numbers in this assay, from the lowest: compounds 3 and 1 (each within the scatter of the next); then compound 2.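

In this assay, replacing 1-(trifluoromethyl)cyclopropyl with 1-(trifluoromethyl)cyclobutyl on a saturated chain carbon bound to an amine nitrogen in a ring is not a neutral change (a number 20 percentage points lower from compound 2 to compound 3 (beyond the scatter)), so the size of this ring matters at this position. The gain seen with the 1-(trifluoromethyl)cyclopropyl group therefore does not extend to its larger neighbour (a number 9 percentage points lower from compound 1 to compound 3 (within the scatter)). Nothing measured here offers a reason for this drop. Open, as far as these compounds go, is whether a 1-(trifluoromethyl)cyclopentyl group would fall further, and whether a plain methyl in place of trifluoromethyl would keep the response of compound 2.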